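This account rests on a few compounds, and the source may have more. Where it says the series, first, only, none or still open, it means among the compounds named here.

In a functional assay on A-375 cells (Homo sapiens) for antiproliferative activity, read by MTT assay, with a stated time of 24 h; on this read-out higher numbers stand for weaker inhibition and lower numbers for stronger inhibition:
- compound 1 `C=CCOc1ccc2c(=O)c(-c3cc(OC)c(OC)cc3OC)coc2c1`: 4750 nM
- compound 2 `COc1cc(OC)c(-c2coc3cc(OCc4ccccc4)ccc3c2=O)cc1OC`: 1640 nM
- compound 3 `COc1cc(OC)c(-c2coc3cc(OCc4ccc(F)cc4)ccc3c2=O)cc1OC`: 1720 nM

Compound 3 stands level with compound 2, as a 1.0-fold higher number from compound 2 to compound 3 (0.02 log units; within the scatter) shows, and both lie under compound 1. The next structure, compound 4 `COc1cc(OC)c(-c2coc3cc(OCc4ccccc4C#N)ccc3c2=O)cc1OC`, is not yet measured: 2-cyanophenyl in place of 4-fluorophenyl on a saturated chain carbon bound to an oxygen on an aromatic ring. The closest evidence is the fluoro in place of hydrogen on the aromatic ring, a 1.0-fold higher number from compound 2 to compound 3 (0.02 log units; within the scatter). The larger changes, a 2.9-fold lower number from compound 1 to compound 2 (0.46 log units; beyond the scatter) and a 2.8-fold lower number from compound 1 to compound 3 (0.44 log units; beyond the scatter), replaced vinyl, which is absent here. Among the compounds with values here, no measured compound carries 2-cyanophenyl, so the estimate stays wide. The expected step, a 1.0-fold higher number from compound 3 to compound 4 (0.02 log units; within the scatter), is none beyond the scatter. For compound 4 the estimated value is 1800 nM, with an expected range of 750 nM to 4300 nM.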

Compound 4, half-maximal inhibitory concentration: 990 nM
Estimate against measurement, compound 4: 1.8-fold (0.26 log units) above, and the stated range covers the measured number.
By their numbers in this assay, from the lowest: compounds 4, 2 and 3 (each within the scatter of the next); then compound 1.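

At the saturated chain carbon bound to an oxygen on an aromatic ring, in this assay, a nitrile on the aromatic group leaves the read-out level with the other aromatic groups: a 1.7-fold lower number from compound 3 to compound 4 (0.24 log units; within the scatter) and a 1.7-fold lower number from compound 2 to compound 4 (0.22 log units; within the scatter). Against vinyl, 2-cyanophenyl gives a 4.8-fold lower number from compound 1 to compound 4 (0.68 log units; beyond the scatter), so all three aromatic groups shown now stand clear of vinyl. No measured data here explain this result. Open, on these data alone, is whether an amine or a carboxylic acid on the aromatic group keeps this level. Also open, as far as these compounds go, is the effect of a longer chain at this place.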